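A few compounds are considered here, and "the series" means these few. Any claim that something is new, unique, unknown or untested is made for them only; others in the source may bear on it.

Measured compounds:
compound 1 `CC(=O)Nc1cccc(C2CCN(CCCn3c(-c4ccccc4C(F)(F)F)nc4ccccc43)CC2)c1` — 50 nM
compound 2 `CC(=O)Nc1cccc(C2CCN(CCCn3c(-c4ccc(Br)cc4)nc4ccccc43)CC2)c1` — 5 nM

For the measured compounds named here, in an assay for displacement of a labelled ligand from melanin-concentrating hormone receptor 1 (Homo sapiens), read by fluorescence (a higher number here means a weaker inhibitor, a lower number a stronger inhibitor), compound 2 stands at the lower of the two numbers, with compound 1 the only neighbour and a higher number. Compound 3 `CC(=O)Nc1cccc(C2CCN(CCCn3c(-c4ccc(F)cc4Cl)nc4ccccc43)CC2)c1` is the unmeasured compound; its change from compound 2 is 2-chloro-4-fluorophenyl in place of 4-bromophenyl on an aromatic carbon. Going by the values given here, the one step that bears on this is a 10-fold lower number from compound 1 to compound 2 (1.00 log units; beyond the scatter), where a 2-(trifluoromethyl)phenyl gave way to 4-bromophenyl. The 2-chloro-4-fluorophenyl of compound 3 carries one halogen in each of those two positions, so a number between the two measured values is expected, most likely a modest rise from compound 2 with a 3.0-fold higher number from compound 2 to compound 3 (0.48 log units; beyond the scatter). Compound 3 is estimated at 15 nM, with a range from 4 nM to 60 nM.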

Compound 3, half-maximal inhibitory concentration: 4 nM
Beside the measured number, compound 3's estimate is 3.8-fold (0.57 log units) above it, within the range that was stated.
By their numbers in this assay, from the lowest: compounds 3 and 2 (each within the scatter of the next); then compound 1.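

In this assay, the aromatic carbon of the shared core accepts 2-chloro-4-fluorophenyl as readily as 4-bromophenyl, with a 1.3-fold lower number from compound 2 to compound 3 (0.10 log units; within the scatter). Compound 1 therefore no longer shows simply that a group on the phenyl ring's 2-position raises the number: 2-chloro-4-fluorophenyl also has one there, yet the comparison gives a 13-fold lower number from compound 1 to compound 3 (1.10 log units; beyond the scatter). No measurement shown explains this difference.

From the compounds shown here alone, the separate contributions of the chlorine and fluorine remain unknown, since 2-chlorophenyl and 4-fluorophenyl are absent from this set. Going by these compounds, whether a phenyl bearing an amine or a carboxylic acid would fit here also remains open.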